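From Isopentyl to Tert-Butyl on the Shared Core

This account rests on a few compounds, and the source may have more. Where it says the series, first, only, none or still open, it means among the compounds named here.

Of the compounds shown here, three built on one shared core have been tested in an in vitro functional assay on cells for agonist activity at Bombesin receptor subtype-3 (Mus musculus), read by luminescence and calcium flux; on this read-out higher numbers stand for an effect only at larger amounts of compound and lower numbers for an effect already at smaller amounts. Compound 1 `O=C(O)c1ccccc1-c1ccc(CCc2ncc(C3CCCCC3)[nH]2)cc1` gives 14.7 nM. Compound 2 `N#Cc1ccc(Cc2cnc(CCc3ccc(-c4ccccc4C(=O)O)cc3)[nH]2)cc1` gives 723 nM. Compound 3 `CC(C)CCc1cnc(CCc2ccc(-c3ccccc3C(=O)O)cc2)[nH]1` gives 10 nM, the lowest of the three numbers shown, although compound 1 sits within the scatter of it, whereas compound 2 lies far off, as seen in a 72-fold lower number from compound 2 to compound 3 (1.86 log units; beyond the scatter). Compound 4 `CC(C)(C)c1cnc(CCc2ccc(-c3ccccc3C(=O)O)cc2)[nH]1` differs from compound 3 in one place: tert-butyl in place of isopentyl on an aromatic carbon. The step that bears most on this change is the earlier swap of one saturated group for another, a 1.5-fold lower number from compound 1 to compound 3 (0.17 log units; within the scatter), which stayed within the scatter. The large moves, a 49-fold higher number from compound 1 to compound 2 (1.69 log units; beyond the scatter) and a 72-fold lower number from compound 2 to compound 3 (1.86 log units; beyond the scatter), came with a group carrying an aromatic ring and a nitrile, and nothing of that kind enters here. A small step is therefore expected for compound 4 in this assay, leaning toward a somewhat higher number, a 2.5-fold higher number from compound 3 to compound 4 (0.40 log units; beyond the scatter). Compound 4 is estimated at 25 nM, with a range from 8 nM to 80 nM.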

Compound 4, half-maximal effective concentration: 2750 nM
Compound 4: middle estimate off by 110-fold (2.04 log units), on the low side; the whole stated range lies below it.
By their numbers in this assay, from the lowest: compounds 3 and 1 (each within the scatter of the next); then compound 2; then compound 4.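

In this assay, tert-butyl on this aromatic carbon gives a 280-fold higher number from compound 3 to compound 4 (2.44 log units; beyond the scatter) and a 190-fold higher number from compound 1 to compound 4 (2.27 log units; beyond the scatter), so this position does not treat all saturated groups alike, even though isopentyl and cyclohexyl stayed within the scatter of each other. Tert-butyl, with 4 heavy atoms against the 5 of isopentyl, adds no ring, nitrile or hydrogen-bond donor or acceptor, yet it also gives a 3.8-fold higher number from compound 2 to compound 4 (0.58 log units; beyond the scatter), so a large rise here does not need a group like 4-cyanobenzyl. No measurement available here accounts for this sharp difference between two small carbon groups.

The compounds shown leave open how isopropyl or neopentyl on this aromatic carbon would read, and so where between isopentyl and tert-butyl the rise sets in. Also open, going by these compounds, is whether a chain ending in an amine would sit with compound 3 or with compound 4.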